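A few compounds are considered here, and "the series" means these few. Any claim that something is new, unique, unknown or untested is made for them only; others in the source may bear on it.

In an ADME assay on microsomes from liver (Homo sapiens) for metabolic stability (on this read-out lower numbers stand for a shorter-lived compound and higher numbers for a longer-lived compound), compound 1 (`COc1cc(OCc2cccc(-c3cnc(OC)nc3)c2)c2cc(-c3cn4nc(OC)sc4n3)oc2c1`) gives 0.6 h as its reading. Compound 3 (`CNC(=O)c1ccc(-c2nc(COc3cc(OC)cc4oc(-c5cn6nc(OC)sc6n5)cc34)cs2)cc1`) gives 0.983 h and lies within the scatter of compound 1. Compound 2 (`COc1cc(OCc2csc(-c3ccc(C(C)(C)O)cc3)n2)c2cc(-c3cn4nc(OC)sc4n3)oc2c1`) gives 1.83 h and stands higher than compound 1 by more than the scatter.

The exchange that leads from compound 1 to compound 4 (`COc1ccc(-c2cccc(COc3cc(OC)cc4oc(-c5cn6nc(OC)sc6n5)cc34)c2)nc1`) is 5-methoxypyridin-2-yl in place of 2-methoxypyrimidin-5-yl on an aromatic carbon and it sits on an aromatic carbon of a six-membered aromatic ring of carbon only, meta to a large group. The only measured step between two of these compounds is a 1.9-fold lower number from compound 2 to compound 3 (0.27 log units; within the scatter) and it lies within the scatter, with methylcarbamoyl in place of 1-hydroxy-1-methylethyl on an aromatic carbon. That step concerns a different group, and no measurement here shows what exchanging 2-methoxypyrimidin-5-yl does. The data therefore give no ground for expecting a step beyond the scatter in this assay and none is expected. The estimated change is a 1.2-fold higher number from compound 1 to compound 4 (0.07 log units; within the scatter) and it is expected to stay within the scatter. For compound 4 the estimate is 0.7 h with an expected range from 0.35 h to 1.4 h around it.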

Compound 4, half-life: 0.767 h
For compound 4 the middle estimate is 1.1-fold (0.04 log units) below the measured one, and the stated range covers the measured number.
By their numbers in this assay, from the lowest: compounds 1, 4, 3 and 2 (each within the scatter of the next, the first and the last beyond it).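

In this assay, among these compounds, the exchange at this position gives a 1.3-fold higher number from compound 1 to compound 4 (0.11 log units; within the scatter) as its step, the first reading for a change on this aromatic carbon, meta to a large group, and it shows that 5-methoxypyridin-2-yl can take the place of 2-methoxypyrimidin-5-yl without leaving the scatter. The two groups hold the same number of heavy atoms, while the entering group has one ring hetero atom where the leaving group has two and 2 hydrogen-bond acceptors where the leaving group has 3, so in this one pair those differences come with no step beyond the scatter. Nothing measured here bears on the cause of this result.

Going by these compounds, it remains open whether a group of another kind on the same aromatic carbon, such as an amine or a carboxylic acid, would also stay within the scatter. Among the compounds shown here, also open is what the ring of carbon only contributes to the reading: compound 2 and compound 3 differ from compound 1 in more than one place, and no single step joins them to it.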